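From tert-butyl to 1-(methoxymethyl)ethyl on a shared core

The compounds below may be only part of what the source reports. "The series", "measured", "known", "first", "only" and "open" are said of these compounds alone.

Compound 1 `CC/C=C\C[C@H]1C(=O)C=C[C@H]1CC(=O)OCCCC` gives 23000 nM
Compound 2 `CC/C=C\C[C@H]1C(=O)C=C[C@H]1CC(=O)OC(C)C` gives 20000 nM
Compound 3 `CC/C=C\C[C@H]1C(=O)C=C[C@H]1CC(=O)OC(C)(C)C` gives 20000 nM

All three values come from a functional assay on RAW264.7 cells (Mus musculus) for inhibition, read by ELISA, with a stated time of 24 h (on this read-out lower numbers stand for an effect already at smaller amounts and higher numbers for an effect only at larger amounts of compound), and share one core, differing only in the group on an oxygen next to a carbonyl group. Compound 3 stands level with compound 2, and compound 1 lies within the scatter of both, the spread expected between repeated measurements.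

The next compound, compound 4 `CC/C=C\C[C@H]1C(=O)C=C[C@H]1CC(=O)OC(C)COC`, has not yet been measured. The change is 1-(methoxymethyl)ethyl in place of tert-butyl on an oxygen next to a carbonyl group, in words 1-(methoxymethyl)ethyl in place of tert-butyl.

Within the data shown here, three measured steps bear on this change: a 1.2-fold lower number from compound 1 to compound 2 (0.06 log units; within the scatter), then a 1.2-fold lower number from compound 1 to compound 3 (0.06 log units; within the scatter), and finally no change at the digits printed from compound 2 to compound 3 (within the scatter). Swapping butyl, isopropyl and tert-butyl on this oxygen thus left the number within the scatter in these three compounds. None of them carries the methoxymethyl part, however, so the data do not test it directly, and the range must stay wide.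

The expected result in this assay is no step beyond the scatter, estimated as a 1.1-fold higher number from compound 3 to compound 4 (0.04 log units; within the scatter) in size. The estimate for compound 4 is 22000 nM, with an expected range from 11000 nM to 45000 nM for the measurement.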

Compound 4, half-maximal effective concentration: 23000 nM
Compound 4: middle estimate off by 1.0-fold (0.02 log units), on the low side; low and high end bracket the measured number.
By their numbers in this assay, from the lowest: compounds 2, 3, 1 and 4 (each within the scatter of the next).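

In this assay, 1-(methoxymethyl)ethyl in place of tert-butyl on an oxygen next to a carbonyl group gives a 1.2-fold higher number from compound 3 to compound 4 (0.06 log units; within the scatter), so this position now also accepts a group with a hydrogen-bond acceptor, which the butyl, isopropyl and tert-butyl groups lack, without a step beyond the scatter. The methoxy part is seen most directly as methoxy in place of hydrogen, with a 1.2-fold higher number from compound 2 to compound 4 (0.06 log units; within the scatter), while the comparison with the unbranched butyl group gives no change at the digits printed from compound 1 to compound 4 (within the scatter). No available measurement explains why these four groups lie within the scatter of one another.

From the compounds shown here alone, all four groups are saturated chains, so it remains open whether the same picture would hold for a group ending in an amine or a carboxylic acid, or for a longer chain on this oxygen. No group at this position has yet produced a step beyond the scatter, and these compounds cannot show whether changes elsewhere on the shared core would do so.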